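Fluoro additions in a small antiproliferative series

The compounds below may be only part of what the source reports. "The series", "measured", "known", "first", "only" and "open" are said of these compounds alone.

Measured in a functional assay on A549 cells (Homo sapiens) for antiproliferative activity, read by MTT assay; a higher number here means a weaker inhibitor, a lower number a stronger inhibitor:
- compound 1 `Cc1nn2c(-c3nc4ccccc4[nH]3)c(-c3ccccc3)nc2s1`: 16600 nM
- compound 2 `Cc1nn2c(-c3nc4cc(F)ccc4[nH]3)c(-c3ccccc3)nc2s1`: a limit of the assay, > 30000 nM
- compound 3 `Cc1ccc(-c2nc3sc(C)nn3c2-c2nc3cc(Cl)ccc3[nH]2)cc1`: 4400 nM

Compound 2 carries fluoro in place of hydrogen on an aromatic carbon. The step of an at least 1.8-fold higher number from compound 1 to compound 2 (0.25 log units; that floor lies within the scatter); its floor rests on (the limit of > 30000 nM in this assay, at which 1 of the 3 values shown sits). How the core of compound 3 differs from the core of compound 1 is not broken down here. Compound 4 `Cc1ccc(-c2nc3sc(C)nn3c2-c2nc3cc(Cl)c(F)cc3[nH]2)cc1` is not yet measured; it carries fluoro in place of hydrogen on an aromatic carbon. The surroundings differ: in compound 4 the fluoro stands ortho to a chloro group, which compound 2 lacks, so this is the same kind of change, not the same. Compound 4 is expected to give 9000 nM, with a range of 3500 nM to 25000 nM. The expected step is a 2.0-fold higher number from compound 3 to compound 4 (0.31 log units; beyond the scatter), resting on compound 2 and the step of an at least 1.8-fold higher number from compound 1 to compound 2 (0.25 log units; that floor lies within the scatter).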

Compound 4, half-maximal inhibitory concentration: 10300 nM
Compound 4: the middle estimate sits 1.1-fold (0.06 log units) below what was measured; the range from low to high includes it.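

In this assay the fluoro addition gives a 2.3-fold higher number from compound 3 to compound 4 (0.37 log units; beyond the scatter), a modest step that can be read as a number. In compound 4 the fluoro stands ortho to a chloro group, so the two cases are the same kind of change in different surroundings, and two cores support no rule for the series. Whether the change costs the same on both cores stays unsettled: the same change on two cores in this assay, an at least 1.8-fold higher number (0.25 log units; that floor lies within the scatter) from compound 1 to compound 2 and a 2.3-fold higher number (0.37 log units; beyond the scatter) from compound 3 to compound 4; the limit leaves it open whether they differ

Still open, from the compounds shown here alone, is how an amine or a carboxylic acid in place of the fluoro would read on the core of compound 3. Also open is what the chloro group contributes, since no pair shown differs in that group alone.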